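This account rests on a few compounds, and the source may have more. Where it says the series, first, only, none or still open, it means among the compounds named here.

Measured so far:
Compound 1 `Oc1ccc(-c2cc(-c3ccc(O)cc3)nc(-c3ccc(O)cc3)c2)cc1` gives 5120 nM in a functional assay on HCT-15 cells (Homo sapiens) for cytotoxicity, read by CCK-8 assay, with a stated time of 4 days; a lower number here means a stronger inhibitor, a higher number a weaker inhibitor.
Compound 2 `Oc1ccc(-c2cc(-c3ccccc3O)cc(-c3ccc(O)cc3)n2)cc1` gives 1920 nM in this assay.

Among the compounds with values here, compound 1 stands as the higher of the two numbers in this assay; the only measured step away from it, a 2.7-fold lower number from compound 1 to compound 2 (0.43 log units; beyond the scatter), is a modest lowering. Compound 3 `Oc1ccc(-c2cc(-c3ccc(O)cc3)nc(-c3cccc(O)c3)c2)cc1` has not yet been measured. It differs from compound 1 by 3-hydroxyphenyl in place of 4-hydroxyphenyl on an aromatic carbon, on an aromatic carbon next to the ring nitrogen of the shared core. Within the data shown here, the one measured step that bears on it, a 2.7-fold lower number from compound 1 to compound 2 (0.43 log units; beyond the scatter), also moved a hydroxyl around a phenyl ring, though on a different carbon of the core and to a different position of the ring, and it lowered the number modestly. On that basis compound 3 is expected to show a small lowering or no step beyond the scatter, estimated as a 1.6-fold lower number from compound 1 to compound 3 (0.20 log units; within the scatter). Compound 3 is therefore expected at 3200 nM, with a range of 1200 nM to 8500 nM in this assay.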

Compound 3, half-maximal inhibitory concentration: 3520 nM
Compound 3: middle estimate off by 1.1-fold (0.04 log units), on the low side, and the stated range covers the measured number.
By their numbers in this assay, from the lowest: compounds 2, 3 and 1 (each within the scatter of the next, the first and the last beyond it).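

In this assay, a 1.5-fold lower number from compound 1 to compound 3 (0.16 log units; within the scatter) shows that exchanging 4-hydroxyphenyl for 3-hydroxyphenyl on the aromatic carbon next to the ring nitrogen gives no step beyond the scatter. The earlier compounds shown here showed only an exchange on a different carbon of the shared core, with 2-hydroxyphenyl as the entering group, and that step lay beyond the scatter. Nothing at hand offers an explanation for this result.

The compounds shown leave open whether 2-hydroxyphenyl on this same carbon would give a step beyond the scatter, so the hydroxyl's place on the ring and the carbon that carries the ring cannot yet be told apart. They also leave open whether a methoxy group, an amine or a carboxylic acid in place of the hydroxyl would change the number.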